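The source may report more compounds than this note shows. Statements on the series, on what has been measured and on what is new or still open speak of the compounds shown alone.

Compound 1 `O=C1C(=Cc2ccc(Cl)cc2)C(=O)N(c2ccc(Cl)cc2)N1c1ccc(Cl)cc1`: 30900 nM
Compound 2 `O=C1C(=Cc2ccc(Br)cc2)C(=O)N(c2ccc(Cl)cc2)N1c1ccc(Cl)cc1`: 16600 nM
Compound 3 `O=C1C(=Cc2ccc(Cl)cc2Cl)C(=O)N(c2ccc(Cl)cc2)N1c1ccc(Cl)cc1`: a limit, > 128000 nM

In a functional assay on SMMC-7721 cells (Homo sapiens) for cytotoxicity, read by MTT assay, with a stated time of 72 h (a higher number here means a weaker inhibitor, a lower number a stronger inhibitor), compound 2 gives the lowest of the two numbers, with compound 1 nearest at a 1.9-fold lower number from compound 1 to compound 2 (0.27 log units; within the scatter). Compound 3 sits at the limit of this assay the limit of > 128000 nM in this assay, at which 1 of the 3 values shown sits, and gives no number. Compound 4 `O=C1C(=C/C=C/c2ccccc2)C(=O)N(c2ccc(Cl)cc2)N1c1ccc(Cl)cc1` is not yet measured; relative to compound 2 the change is 2-phenylethenyl in place of 4-bromophenyl on a double-bonded chain carbon bound to a double-bonded ring carbon.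

For the measured compounds named here, two measured steps bear on that position of the shared core. The halogen swap a 1.9-fold lower number from compound 1 to compound 2 (0.27 log units; within the scatter) stayed within the scatter. The change to a dichlorinated ring an at least 7.7-fold higher number from compound 2 to compound 3 (0.88 log units; beyond the scatter) went beyond the scatter toward a weaker inhibitor and ended at the limit. Neither step covers a 2-phenylethenyl group or the loss of the bromine, so the direction for compound 4 is uncertain; the expectation is a step of no more than modest size, most likely toward a higher number, expressed as a 1.8-fold higher number from compound 2 to compound 4 (0.26 log units; within the scatter). Compound 4 is therefore estimated at 30000 nM, with a range from 10000 nM to 100000 nM.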

Compound 4, half-maximal inhibitory concentration: 10100 nM
For compound 4 the middle estimate is 3.0-fold (0.47 log units) above the measured one, and the stated range covers the measured number.
By their numbers in this assay, from the lowest: compounds 4, 2 and 1 (each within the scatter of the next, the first and the last beyond it). At a limit, above all of these: compound 3.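

In this assay, the position on a double-bonded chain carbon bound to a double-bonded ring carbon tolerates 2-phenylethenyl, which carries no halogen, in place of 4-bromophenyl: a 1.6-fold lower number from compound 2 to compound 4 (0.22 log units; within the scatter). Against 4-chlorophenyl, the same group gives a 3.1-fold lower number from compound 1 to compound 4 (0.49 log units; beyond the scatter), so the modest step appears only in this comparison, and it does not extend to compound 2. Compound 3 stands at a limit, so an at least 12-fold lower number from compound 3 to compound 4 (1.10 log units; beyond the scatter) gives only a bound on the size of the step: the limit of > 128000 nM in this assay, at which 1 of the 4 values shown sits.

The compounds shown do not separate the effect of the ethenyl link from that of losing the halogen, since none has a plain phenyl at this position or a chloro on the ring of 2-phenylethenyl. Also open, going by these compounds, is how a longer chain, or an amine or carboxylic acid on that ring, would read out here.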